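Carbocyclic purine analogues: cyclopropylamino step

A few compounds are considered here, and "the series" means these few. Any claim that something is new, unique, unknown or untested is made for them only; others in the source may bear on it.

Measured so far in a functional assay on CCRF-CEM cells (Homo sapiens), with a stated time of 72 h; a higher number here means a weaker inhibitor, a lower number a stronger inhibitor:
compound 1, `Nc1nc(Cl)c2ncn([C@@H]3C[C@@]4(CO)CC[C@@H]3C4)c2n1`, gives 88000 nM
compound 2, `Nc1nc(N)c2ncn([C@@H]3C[C@@]4(CO)CC[C@@H]3C4)c2n1`, gives 174000 nM

Compound 2 holds the higher of the two numbers in this assay, but the step of a 2.0-fold higher number from compound 1 to compound 2 (0.30 log units; within the scatter) lies within the scatter, so the two compounds are not separated. Compound 3, `Nc1nc(NC2CC2)c2ncn([C@@H]3C[C@@]4(CO)CC[C@@H]3C4)c2n1`, differs from compound 2 by cyclopropyl in place of hydrogen on a nitrogen on an aromatic ring. Within the data shown here, no measured step touches substitution on that nitrogen; the single measured step concerns the chloro-to-amino exchange only, so no direction can be drawn. For compound 3 the number in this assay is therefore expected near that of compound 2, with a wide range, giving an expected step of a 1.5-fold lower number from compound 2 to compound 3 (0.16 log units; within the scatter). The estimate for compound 3 is 120000 nM, between 20000 nM and 600000 nM.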

Compound 3, half-maximal inhibitory concentration: 124000 nM
The estimate for compound 3 lay 1.0-fold (0.01 log units) below the measured number; the measured number falls inside the stated range.
By their numbers in this assay, from the lowest: compounds 1, 3 and 2 (each within the scatter of the next).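

In this assay, cyclopropyl on this nitrogen gives a 1.4-fold lower number from compound 2 to compound 3 (0.15 log units; within the scatter), so the added ring produces no step beyond the scatter. Cyclopropylamino in place of chloro on an aromatic carbon gives a 1.4-fold higher number from compound 1 to compound 3 (0.15 log units; within the scatter), leaving chloro, amino and cyclopropylamino unseparated at this carbon across these three compounds. No available evidence bears on this result.

Still open, going by these compounds, is whether a longer alkyl chain or a phenyl ring on this nitrogen would give a step beyond the scatter. The same question stands for methoxy in place of chloro on the aromatic carbon.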